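Amide nitrogen variation: from compound 3 to compound 4

The compounds below may be only part of what the source reports. "The series", "measured", "known", "first", "only" and "open" are said of these compounds alone.

Values come from a functional assay on the whole organism (strain Wistar) for inhibition, with Rattus norvegicus as the target, read by paw edema, with stated times of 60 min and 1 h, at a dose of 100 mg/kg by the oral route; on this read-out higher numbers stand for more inhibition at the one dose given (going by the name of the read-out) and lower numbers for less inhibition:
- compound 1 `CNC(=O)CC1CCc2cc(OC)c(OC)cc21` gives 15.6%
- compound 2 `CCN(CC)C(=O)CC1CCc2cc(OC)c(OC)cc21` gives 31.3%
- compound 3 `COc1cc2c(cc1OC)C(CC(=O)NC(C)C)CC2` gives 31.3%

Compound 3 stands level with compound 2, the two together the highest of the three numbers. The step of a number 15.7 percentage points higher from compound 1 to compound 3 (beyond the scatter) lies beyond the scatter, whereas no change at the digits printed from compound 2 to compound 3 (within the scatter).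

Compound 4 `COc1cc2c(cc1OC)C(CC(=O)N1CCCCC1)CC2` has not been measured. It differs from compound 3 in one place: piperidin-1-yl in place of isopropylamino on a carbonyl carbon. For the measured compounds named here, two measured steps bear on this. The exchange no change at the digits printed from compound 2 to compound 3 (within the scatter) shows that diethylamino and isopropylamino on the carbonyl carbon give the same number, so the presence or absence of the amide hydrogen did not matter between those two. The step of a number 15.7 percentage points higher from compound 1 to compound 2 (beyond the scatter) shows that diethylamino gives a higher number than methylamino. Piperidin-1-yl, like diethylamino, carries no hydrogen-bond donor. Compound 4 is therefore expected to stay close to compound 3, with an estimated step of a number 1.7 percentage points higher from compound 3 to compound 4 (within the scatter), not beyond the scatter. For compound 4 the estimate in this assay is 33%, with a range from 18% to 48%.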

Compound 4, a percentage reported as inhibition, in the whole organism at one dose (the size of the read-out at that dose, not a potency): 18.8%
The estimate for compound 4 lay 14.2 percentage points above the measured number; measured number inside the range.
By their numbers in this assay, from the lowest: compounds 1 and 4 (each within the scatter of the next); then compounds 2 and 3 (each within the scatter of the next).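

In this assay, the missing amide hydrogen does not set the level on this carbonyl carbon: piperidin-1-yl and diethylamino both lack it, yet the record reads a number 12.5 percentage points lower from compound 2 to compound 4 (beyond the scatter) and the ring is thus separated from the open-chain amide. The comparison with the secondary amide reads a number 12.5 percentage points lower from compound 3 to compound 4 (beyond the scatter) and the comparison with the methylamino amide reads a number 3.2 percentage points higher from compound 1 to compound 4 (within the scatter) so that among these amides, a high number does not follow simply from a larger group, since piperidin-1-yl has more heavy atoms than isopropylamino. No supporting measurement is available to account for the lower number of the piperidin-1-yl amide.

The compounds shown leave open whether this lower number goes with rings on the amide nitrogen in general or with piperidin-1-yl alone, a question that pyrrolidin-1-yl or morpholin-4-yl on the carbonyl carbon would address. Also open, on these data alone, is how a carboxylic acid in place of the amide would read at this dose.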